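From Cyclopropyl to Benzyl: A Half-Life Question

The source may report more compounds than this note shows. Statements on the series, on what has been measured and on what is new or still open speak of the compounds shown alone.

In an ADME assay on microsomes from liver (Homo sapiens) for metabolic stability (on this read-out higher numbers stand for a longer-lived compound and lower numbers for a shorter-lived compound), compound 3 (`O=C1NC(=O)/C(=C/C(c2ccc(-c3ccc4cccc(F)c4c3)[nH]c2=O)C2CC2)O1`) gives 1.98 h as its half-life. This lies within the usual scatter of compound 2 (`CC(C)C(c1ccc(-c2ccc3cccc(F)c3c2)[nH]c1=O)C1SC(=O)NC1=O`) at 1.87 h in this assay as well. Compound 1 (`CCc1cccc2ccc(-c3ccc(C(/C=C4\OC(=O)NC4=O)(CC)CC)c(=O)[nH]3)cc12`) reads 0.178 h and so is clearly shorter-lived than compound 3, beyond the scatter.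

The next molecule is compound 4 (`O=C1NC(=O)/C(=C/C(Cc2ccccc2)c2ccc(-c3ccc4cccc(F)c4c3)[nH]c2=O)O1`). The change from compound 3 is benzyl in place of cyclopropyl on a saturated chain carbon bound to an aromatic carbon and a double-bonded chain carbon and it falls on a saturated chain carbon bound to an aromatic carbon and a double-bonded chain carbon. In short, benzyl stands in place of cyclopropyl.

Within the data shown here, no two measured compounds differ in just one place, so the data show no direct example of what a single swap does in this assay here. A modest shortening of the half-life is expected, near the edge of the scatter, and the estimated step is a 1.8-fold lower number from compound 3 to compound 4 (0.26 log units; within the scatter) with real uncertainty in both directions. Compound 4 is estimated at 1.1 h with an expected range from 0.4 h to 2.2 h for its half-life.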

Compound 4, half-life: 1.3 h
Estimate against measurement, compound 4: 1.2-fold (0.07 log units) below, within the range that was stated.
By their numbers in this assay, from the lowest: compound 1; then compounds 4, 2 and 3 (each within the scatter of the next).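

Among these compounds, this is the first comparison here in which only one place changes. In this assay, the swap of cyclopropyl for benzyl gives a 1.5-fold lower number from compound 3 to compound 4 (0.18 log units; within the scatter), so on a saturated chain carbon bound to an aromatic carbon and a double-bonded chain carbon, a group of 3 heavy atoms can give way to one of 7 heavy atoms, with an added six-membered aromatic ring, without a change beyond the scatter. Nothing available explains why the two half-lives stay so close.

This single pair cannot show whether the same swap would behave alike on another core, such as that of compound 1. It also leaves open how a group of a different kind at this place, such as an amine or a carboxylic acid, would affect the half-life.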